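Adding one chloro to a compound at the assay limit

The compounds below may be only part of what the source reports. "The series", "measured", "known", "first", "only" and "open" are said of these compounds alone.

Compound 1 `CCOC(=O)c1c(-c2cccc(Oc3ccccc3)c2)[nH]c2cc(OC)ccc2c1=O` gives > 22000 nM
Compound 2 `CCOC(=O)c1c(-c2cccc(OC(F)(F)F)c2)[nH]c2cc(OC)ccc2c1=O` gives > 22000 nM
Compound 3 `CCOC(=O)c1c(-c2cccc(C(C)=O)c2)[nH]c2cc(OC)ccc2c1=O` gives > 22000 nM

In an ADME assay on HEK293 cells (Homo sapiens) for cytotoxicity, read by luminescence, with a stated time of 72 h (a lower number here means that less compound is needed, a higher number that more compound is needed for the effect), compound 1 gives > 22000 nM as a limit and not a number. All three measured compounds stand at the limit of > 22000 nM in this assay, at which 3 of the 3 values shown sit, and so none can be ranked against another.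

Compound 4 `CCOC(=O)c1c(-c2cccc(Oc3ccccc3)c2)[nH]c2cc(OC)c(Cl)cc2c1=O` differs from compound 1 by one group (chloro in place of hydrogen on an aromatic carbon) on the shared core. The nearest evidence is a step that the two limits leave unreadable from compound 1 to compound 2 together with a step that the two limits leave unreadable from compound 1 to compound 3 and a step that the two limits leave unreadable from compound 2 to compound 3 as the third. All three exchange the phenoxy, trifluoromethoxy or acetyl group, not the hydrogen that leaves here, and none has a readable size. The data therefore give no measured sign of a step beyond the scatter in this assay and no direction for one. The expected outcome is a number no higher from compound 1 to compound 4 (the limit leaves the size open) with neither direction favoured. Compound 4 is estimated at about 22000 nM with an expected range from 10000 nM to 30000 nM and the result may well be only a limit again.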

Compound 4, half-maximal effective concentration: > 22000 nM
Compound 4 ended at the assay's limit; the forecaster's own chance of this, stated with the estimate: 85%; the middle value lies on the limit itself.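

Compound 1 and compound 4 each give a limit and not a number in this assay, so the step to compound 4 cannot be read: the limit of > 22000 nM in this assay, at which 4 of the 4 values shown sit.

The compounds shown leave open whether adding the chloro changes the concentration needed, and how these four compounds rank.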